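Amino for Chloro on Two Purine-Derived Benzyl Chlorides

A few compounds are considered here, and "the series" means these few. Any claim that something is new, unique, unknown or untested is made for them only; others in the source may bear on it.

Measured so far:
- compound 1 `Nc1nc(Cl)c2ncn(Cc3ccc(CCl)cc3)c2n1`: 34700 nM
- compound 2 `ClCc1cccc(Cn2cnc3c(Cl)nc(Cl)nc32)c1`: 3710 nM
- compound 3 `ClCc1ccc(Cn2cnc3c(Cl)nc(Cl)nc32)cc1`: 3630 nM

The values above were obtained in a functional assay on MDA-MB-231 cells (Homo sapiens) for cytotoxicity, read by sulforhodamine B assay, with a stated time of 48 h; a higher number here means a weaker inhibitor of growth, a lower number a stronger inhibitor of growth. Compound 2 and compound 3 have the same atoms joined differently; the difference between the two cores is not broken down here, and their values lie within the scatter of each other. From compound 3 to compound 1 the change is amino in place of chloro on an aromatic carbon, and it gave a 9.6-fold higher number from compound 3 to compound 1 (0.98 log units; beyond the scatter).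

Compound 4 `Nc1nc(Cl)c2ncn(Cc3cccc(CCl)c3)c2n1` has not yet been measured. It arises from compound 2 by amino in place of chloro on an aromatic carbon, the same change as from compound 3 to compound 1, at a place described in the same words. The step from compound 2 to compound 4 in this assay is therefore expected to be a 9.4-fold higher number from compound 2 to compound 4 (0.97 log units; beyond the scatter), resting on the step from compound 3 to compound 1 and on the value of compound 2. For compound 4 the estimated result is 35000 nM.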

Compound 4, concentration for total growth inhibition: 28800 nM
The estimate for compound 4 lay 1.2-fold (0.08 log units) above the measured number; measured number inside the range.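

In this assay, amino in place of chloro on an aromatic carbon gave a 7.8-fold higher number from compound 2 to compound 4 (0.89 log units; beyond the scatter), and the two steps in this series agree in direction and size: the same change on two cores in this assay, a 9.6-fold higher number (0.98 log units; beyond the scatter) from compound 3 to compound 1 and a 7.8-fold higher number (0.89 log units; beyond the scatter) from compound 2 to compound 4, 1.2-fold (0.09 log units) apart, within the scatter of two such steps. Across these two pairs, then, the change carried from one core to the other. This does not show that it would carry to any further core, and the numbers do not say why they rise.

The compounds shown leave open how a methylamino or methoxy group on that aromatic carbon would compare with amino and chloro. Also open, on these data alone, is what a hydroxymethyl or methyl group in place of the chloromethyl group would do to these numbers.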